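Methyl in place of trifluoromethyl on the carbonyl-bound phenyl

The source may report more compounds than this note shows. Statements on the series, on what has been measured and on what is new or still open speak of the compounds shown alone.

Compound 1 `NC(=O)c1c(NC(=O)c2ccccc2Cl)sc2c1CCN(C(=S)Nc1cc(C(F)(F)F)cc(C(F)(F)F)c1)C2` gives 48900 nM in a functional assay on HeLa cells (Homo sapiens) for antiproliferative activity, with a stated time of 24 h; on this read-out lower numbers stand for stronger inhibition and higher numbers for weaker inhibition.
Compound 2 `NC(=O)c1c(NC(=O)c2ccccc2F)sc2c1CCN(C(=S)Nc1cc(C(F)(F)F)cc(C(F)(F)F)c1)C2` gives 28000 nM in this assay.
Compound 3 `NC(=O)c1c(NC(=O)c2ccc(C(F)(F)F)cc2)sc2c1CCN(C(=S)Nc1cc(C(F)(F)F)cc(C(F)(F)F)c1)C2` gives 49000 nM in this assay.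

Compound 3 has the highest of the three numbers, but it cannot be set apart from the others: a 1.0-fold higher number from compound 1 to compound 3 (0.00 log units; within the scatter) and a 1.8-fold higher number from compound 2 to compound 3 (0.24 log units; within the scatter). The three measured compounds therefore look alike on this read-out, and none can be called stronger or weaker than another.

Compound 4 `Cc1ccc(C(=O)Nc2sc3c(c2C(N)=O)CCN(C(=S)Nc2cc(C(F)(F)F)cc(C(F)(F)F)c2)C3)cc1` has not been measured. It differs from compound 3 in a single place: methyl in place of trifluoromethyl on an aromatic carbon. Going by the values given here, the steps that bear on this all touch the same aryl group on the carbonyl carbon. Exchanging one halogen for another there gave a 1.7-fold lower number from compound 1 to compound 2 (0.24 log units; within the scatter); exchanging a 2-chlorophenyl or a 2-fluorophenyl for the 4-(trifluoromethyl)phenyl gave the two steps named above. Every change so far on that ring left the number within the scatter. The move from compound 3 to compound 4 is a further change on the same ring, and on the evidence at hand no step beyond the scatter is expected: a 1.1-fold lower number from compound 3 to compound 4 (0.04 log units; within the scatter). Compound 4 is thus estimated at 45000 nM, with a range from 20000 nM to 100000 nM.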

Compound 4, half-maximal inhibitory concentration: 17100 nM
Beside the measured number, compound 4's estimate is 2.6-fold (0.42 log units) above it, outside the stated range (below it).
By their numbers in this assay, from the lowest: compounds 4, 2, 1 and 3 (each within the scatter of the next, the first and the last beyond it).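

Methyl in place of trifluoromethyl gives the first step on this aryl ring that lies beyond the scatter (a 2.9-fold lower number from compound 3 to compound 4 (0.46 log units; beyond the scatter)), so the group at this place on the ring can shift the number in this assay, even though the earlier changes on the ring did not separate any of the compounds. The 4-methylphenyl group also stands apart from the 2-chlorophenyl group (a 2.9-fold lower number from compound 1 to compound 4 (0.46 log units; beyond the scatter)), but not from the 2-fluorophenyl group (a 1.6-fold lower number from compound 2 to compound 4 (0.21 log units; within the scatter)), so the gain is modest and does not set it apart from every aryl group shown. Nothing measured here explains why this small exchange moves the number.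

The compounds shown leave open whether the trend holds for other groups at the same place on the ring, such as an ethyl group, a longer chain, a methoxy group, an amine or a carboxylic acid. They also leave open whether the same exchange would give a step of similar size with a different group on the far side of the shared core, since that part stays the same in all four compounds.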